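Larger Polar Side Chain Replaces the Hydroxyethyl Group

The source may hold more compounds than are shown below. What is called first, only, known or untested is meant among the compounds shown, and "the series" means these compounds.

Three compounds built on one shared core differ only in the group on a saturated chain carbon bound to an amide-type nitrogen and a carbonyl carbon. In a functional assay on the whole organism (Tail, strain ICR) with Mus musculus as the target, in the tail flick test, with a stated time of 30 min, at a dose of 25 umol/kg by the oral route (on this read-out higher numbers stand for a stronger effect at the one dose given and lower numbers for a weaker effect), compound 1 `C[C@H](NC(=O)CN(c1nc(Cl)nc2[nH]cnc12)C1CC1)C(=O)OCc1ccccc1` gives 41.2%, compound 2 `O=C(CN(c1nc(Cl)nc2[nH]cnc12)C1CC1)NCC(=O)OCc1ccccc1` gives 18.7%, and compound 3 `C[C@@H](O)[C@H](NC(=O)CN(c1nc(Cl)nc2[nH]cnc12)C1CC1)C(=O)OCc1ccccc1` gives 21.9%. Compound 3 therefore stands second highest of the three numbers: its value and that of compound 2 lie within the scatter of each other, whereas the step of a number 19.3 percentage points lower from compound 1 to compound 3 (beyond the scatter) lies beyond it, as does the step of a number 22.5 percentage points lower from compound 1 to compound 2 (beyond the scatter). The step of a number 3.2 percentage points higher from compound 2 to compound 3 (within the scatter) shows that putting 1-hydroxyethyl in place of hydrogen left the read-out essentially unchanged.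

Compound 4 `N=C(N)NCCC[C@H](NC(=O)CN(c1nc(Cl)nc2[nH]cnc12)C1CC1)C(=O)OCc1ccccc1` carries the change (a group of 7 heavy atoms (4 carbon, 3 nitrogen; no ring) in place of a group of 3 heavy atoms (2 carbon, 1 oxygen; no ring), on a saturated chain carbon bound to an amide-type nitrogen and a carbonyl carbon). Going by the values given here, no measured step tests a group of this size or kind; the steps that lead to compound 3 show only that leaving methyl lowered the number and that exchanging hydrogen for 1-hydroxyethyl changed little. On that basis no step beyond the scatter is expected, and compound 4 is expected to give 22%, between 8% and 42%, in this assay. This estimate means a step of a number 0.1 percentage points higher from compound 3 to compound 4 (within the scatter), with wide uncertainty on either side.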

Compound 4, a percentage reported as activity, at one dose (the size of the read-out at that dose, not a potency): 23.2%
Compound 4: middle estimate off by 1.2 percentage points, on the low side; low and high end bracket the measured number.
By their numbers in this assay, from the lowest: compounds 2, 3 and 4 (each within the scatter of the next); then compound 1.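

In this assay, the place on a saturated chain carbon bound to an amide-type nitrogen and a carbonyl carbon now carries a group of 7 heavy atoms (4 carbon, 3 nitrogen), and the result is a number 1.3 percentage points higher from compound 3 to compound 4 (within the scatter), with a number 4.5 percentage points higher from compound 2 to compound 4 (within the scatter), so this group cannot be told apart from 1-hydroxyethyl or a hydrogen atom here. Methyl remains apart from this new group too, with a number 18 percentage points lower from compound 1 to compound 4 (beyond the scatter), which extends the gap already seen for the other two compounds to a much bigger group with 3 hydrogen-bond donors. Group size alone therefore does not order these four compounds: the hydrogen atom and the group of 7 heavy atoms give numbers within the scatter of each other, and only methyl stands beyond it.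

No supporting measurement bears on why methyl stands apart from the other groups. Still open, as far as these compounds go, is whether an ethyl or isopropyl group at this place would stay with methyl, and whether a shorter chain ending in an amine or a carboxylic acid would stay with compound 4.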